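Heteroaryl Swap on the Sulfonamide Nitrogen: Compound 3 Expected

The compounds below may be only part of what the source reports. "The series", "measured", "known", "first", "only" and "open" are said of these compounds alone.

Compound 1, `C=C1CC[C@@H]2[C@](C)(COC(C)=O)[C@H](OC(C)=O)CC[C@@]2(C)[C@H]1CC(Nc1ccc(S(=O)(=O)Nc2nccs2)cc1)C1=CCOC1=O`, gives 2360 nM in a functional assay on NCI-H226 cells (Homo sapiens) for inhibition, read by sulforhodamine B assay, with a stated time of 48 h; on this read-out lower numbers stand for stronger inhibition of growth and higher numbers for weaker inhibition of growth.
Compound 2, `C=C1CC[C@@H]2[C@](C)(COC(C)=O)[C@H](OC(C)=O)CC[C@@]2(C)[C@H]1CC(Nc1ccc(S(=O)(=O)Nc2ccc(Cl)nn2)cc1)C1=CCOC1=O`, gives 1670 nM in this assay.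

For the measured compounds named here, compound 2 holds the lowest of the two numbers, but the only step between the measured pair, a 1.4-fold lower number from compound 1 to compound 2 (0.15 log units; within the scatter), is within the scatter, so the two values cannot be ordered with confidence.

Compound 3, `C=C1CC[C@@H]2[C@](C)(COC(C)=O)[C@H](OC(C)=O)CC[C@@]2(C)[C@H]1CC(Nc1ccc(S(=O)(=O)Nc2ncccn2)cc1)C1=CCOC1=O`, differs from compound 2 by pyrimidin-2-yl in place of 6-chloropyridazin-3-yl on a sulfonamide nitrogen. Going by the values given here, the one measured step that bears on this change is the earlier exchange on the same sulfonamide nitrogen, a 1.4-fold lower number from compound 1 to compound 2 (0.15 log units; within the scatter), which left the number essentially unchanged. Nothing in the data points to the pyrimidin-2-yl group behaving differently from the two heteroaryl groups already tried, and the scaffold is otherwise identical. The step of a 1.1-fold higher number from compound 2 to compound 3 (0.06 log units; within the scatter) is therefore expected to stay within the scatter, with no clear direction. Compound 3 is accordingly estimated at 1900 nM in this assay, with a plausible range from 800 nM to 4500 nM, and the measurement will show whether that expectation holds.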

Compound 3, concentration for 50% growth inhibition: 1630 nM
Compound 3: middle estimate off by 1.2-fold (0.07 log units), on the high side; measured number inside the range.
By their numbers in this assay, from the lowest: compounds 3, 2 and 1 (each within the scatter of the next).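

In this assay, pyrimidin-2-yl in place of 6-chloropyridazin-3-yl on the sulfonamide nitrogen gives a 1.0-fold lower number from compound 2 to compound 3 (0.01 log units; within the scatter), and pyrimidin-2-yl in place of 1,3-thiazol-2-yl gives a 1.4-fold lower number from compound 1 to compound 3 (0.16 log units; within the scatter). A third heteroaryl group at this position therefore leaves all three compounds within the scatter of one another, which a single exchange could not show, and the chlorine of the 6-chloropyridazin-3-yl group can leave without a step beyond the scatter. No measured information is available here that would explain why these exchanges produce no clear step.

All three compounds carry a heteroaryl ring on this nitrogen, so the compounds shown leave open whether the number would stay in the same range with a plain phenyl ring, an acetyl group or a simple hydrogen there. They also leave open whether a change elsewhere on the shared core, such as free hydroxyl groups in place of the two acetate esters, would produce a step beyond the scatter.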